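Replacing an Aromatic Group with a Hexyl Chain

The source may hold more compounds than are shown below. What is called first, only, known or untested is meant among the compounds shown, and "the series" means these compounds.

Measured so far:
compound 1 `CC(C)(C)N(NC(=O)c1ccccc1)C(=O)c1ccccc1Br`: 170 nM
compound 2 `COc1ccccc1C(=O)N(NC(=O)c1ccccc1)C(C)(C)C`: 525 nM

In an assay on cells for agonist activity at ecdysone receptor (Bombyx mori), read by a luciferase reporter, with a stated time of 24 h (on this read-out lower numbers stand for an effect already at smaller amounts and higher numbers for an effect only at larger amounts of compound), compound 1 gives 170 nM, and compound 2 gives 525 nM, the highest of the two numbers, reached through a 3.1-fold higher number from compound 1 to compound 2 (0.49 log units; beyond the scatter). Compound 3 `CCCCCCC(=O)N(NC(=O)c1ccccc1)C(C)(C)C` differs from compound 2 by hexyl in place of 2-methoxyphenyl on a carbonyl carbon. Within the data shown here, no measured step bears directly on this change; the single known step, a 3.1-fold higher number from compound 1 to compound 2 (0.49 log units; beyond the scatter), exchanges one substituent on the aromatic ring while the ring itself stays. Losing the ring entirely is an untested move, and compound 3 is expected to give a clearly higher number in this assay, estimated at 5000 nM within 1000 nM to 40000 nM, meaning a 9.5-fold higher number from compound 2 to compound 3 (0.98 log units; beyond the scatter).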

Compound 3, half-maximal effective concentration: 7240 nM
Estimate against measurement, compound 3: 1.4-fold (0.16 log units) below; the measured number falls inside the stated range.
By their numbers in this assay, from the lowest: compound 1; then compound 2; then compound 3.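

Hexyl in place of 2-methoxyphenyl on a carbonyl carbon gives a 14-fold higher number from compound 2 to compound 3 (1.14 log units; beyond the scatter) in this assay, and the same chain in place of 2-bromophenyl gives a 43-fold higher number from compound 1 to compound 3 (1.63 log units; beyond the scatter) on the same read-out. Both steps are large, whereas the exchange of bromo for methoxy on the ring, a 3.1-fold higher number from compound 1 to compound 2 (0.49 log units; beyond the scatter), is modest, so removing the whole aromatic group here weighs far more than the one substituent exchange shown. Nothing measured here accounts for this.

The compounds shown leave open whether a cyclohexyl group would behave like the aromatic groups or like hexyl. They also leave open how a butyl or octyl chain would compare with hexyl.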